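Trimming a Hydroxypropyl Arm to Ethyl

The source may hold more compounds than are shown below. What is called first, only, known or untested is meant among the compounds shown, and "the series" means these compounds.

Of the compounds shown here, two have been tested so far in an in vitro functional assay on cells for agonist activity at Bombesin receptor subtype-3 (Homo sapiens), read by luminescence and calcium flux; on this read-out higher numbers stand for an effect only at larger amounts of compound and lower numbers for an effect already at smaller amounts. Compound 1 `O=C(O)c1ccccc1-c1ccc(CCc2ncc(CCC3CCCCC3)[nH]2)cc1` gives 642 nM in this assay. Compound 2 `CCCCc1cnc(C(CCCO)Cc2ccc(-c3ccccc3C(=O)O)cc2)[nH]1` gives 1900 nM in this assay, the highest of the two numbers; its nearest neighbour is compound 1, whose number is lower by a margin that lies beyond the usual scatter.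

Compound 3 `CCCCc1cnc(C(CC)Cc2ccc(-c3ccccc3C(=O)O)cc2)[nH]1` has not yet been measured in this assay. It differs from compound 2 by hydrogen in place of hydroxymethyl on a saturated chain carbon, three bonds along the chain from an aromatic carbon. Within the data shown here, no pair of measured compounds shows this kind of change, so there is no measured step to lean on, and the two measured compounds share only their carboxylic-acid-bearing biaryl core.

Starting from compound 2 at 1900 nM, a small step is expected for compound 3 in this assay, a 1.3-fold lower number from compound 2 to compound 3 (0.10 log units; within the scatter), with the direction uncertain and perhaps not beyond the scatter. Compound 3 is therefore estimated to give 1500 nM in this assay, within a range from 500 nM to 4500 nM.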

Compound 3, half-maximal effective concentration: 2720 nM
For compound 3 the middle estimate is 1.8-fold (0.26 log units) below the measured one; the measured number falls inside the stated range.
By their numbers in this assay, from the lowest: compound 1; then compounds 2 and 3 (each within the scatter of the next).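

In this assay, trimming the 3-hydroxypropyl arm to ethyl gives a 1.4-fold higher number from compound 2 to compound 3 (0.16 log units; within the scatter), a step that stays within the usual scatter. Among these compounds, this is the first measured pair to show this change, and it shows that removing the hydroxymethyl, with its one hydrogen-bond donor and one hydrogen-bond acceptor, produces no difference that this read-out can separate from the scatter of repeat measurements. The hydroxyl-bearing arm therefore shows no measurable contribution at this position in this pair, and no outside measurement is available to explain that result.

From the compounds shown here alone, whether a longer chain on this carbon, or an amine or a carboxylic acid at the end of the arm, would move the number beyond the scatter remains open. Compound 1 differs from compound 2 and compound 3 in more than one place, so it cannot isolate what this arm does, and a single pair cannot show whether the same change would behave alike in another compound.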